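The source may hold more compounds than are shown below. What is called first, only, known or untested is meant among the compounds shown, and "the series" means these compounds.

For the measured compounds named here, in a functional assay on SGC-7901 cells (Homo sapiens) for antiproliferative activity, read by MTT assay, with a stated time of 72 h (on this read-out higher numbers stand for weaker inhibition and lower numbers for stronger inhibition), compound 1 (`C=C1C(=O)[C@@]23C(=O)OC[C@]4(C(=O)CCC(C)(C)[C@H]4C=O)[C@@H]2CC[C@@H]1[C@H]3O`) gives 19500 nM as its reading, the lowest of the two numbers measured so far. In this assay compound 2 (`C=C1C(=O)[C@@]23C(=O)OC[C@]4([C@@H](OC(C)=O)CCC(C)(C)[C@H]4C=O)[C@@H]2CC[C@@H]1[C@H]3O`) gives 49800 nM as its reading. That gap lies beyond the usual scatter, so compound 1 is the stronger inhibitor of the pair.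

Compound 3 (`C=C1C(=O)[C@@]23C(=O)OC[C@]4(C(=O)CCC(C)(C)[C@H]4C=O)[C@@H]2CC[C@@H]1[C@H]3OC(=O)CCCCC1CCSS1`) has not yet been measured. It keeps the core of compound 1 and differs in one place (a group of 11 heavy atoms (8 carbon, 1 oxygen, 2 sulfur; one five-membered non-aromatic ring with 2 hetero atoms) in place of a hydrogen atom, on an oxygen on a saturated carbon), on an oxygen on a saturated carbon. Both measured compounds carry only a hydrogen atom on that oxygen, so neither shows directly what a new group there would do. A change of this size could move the number either way, and the data cannot settle the direction. A moderate gain in inhibition seems the likelier outcome, though this is a judgement rather than a finding. The expected change is a 2.4-fold lower number from compound 1 to compound 3 (0.39 log units; beyond the scatter) as a modest, tentative step towards a lower number. For compound 3 the estimated value is 8000 nM with an expected range from 2000 nM to 25000 nM on this reading.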

Compound 3, half-maximal inhibitory concentration: 6430 nM
Estimate against measurement, compound 3: 1.2-fold (0.09 log units) above; the measured number falls inside the stated range.
By their numbers in this assay, from the lowest: compound 3; then compound 1; then compound 2.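

In this assay, placing the group of 11 heavy atoms, with its five-membered non-aromatic ring holding 2 hetero atoms, on the oxygen in place of the hydrogen atom gives a 3.0-fold lower number from compound 1 to compound 3 (0.48 log units; beyond the scatter). Compound 1 and compound 2 both carry only a hydrogen atom on this oxygen, so they could not show whether it must stay free; compound 3 shows that this oxygen on a saturated carbon can carry a sizeable group without loss of inhibition in these cells, and that, for this one group, inhibition becomes stronger. No supporting measurement is available to say where this gain comes from.

With only one group on this oxygen, the compounds shown cannot separate the part played by the chain from that of the ring with its two sulfur atoms, so a plain carbon chain, a much shorter acetyl group or a chain ending in an amine could each behave differently here. As far as these compounds go, it also remains open whether the same change would bring a similar gain on compound 2, which differs from compound 1 elsewhere in the molecule.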